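Fluorophenyl change from compound 3 to compound 4

A few compounds are considered here, and "the series" means these few. Any claim that something is new, unique, unknown or untested is made for them only; others in the source may bear on it.

Measured in an ADME assay on MT4 cells (Homo sapiens) for cytotoxicity; a higher number here means that more compound is tolerated, a lower number that less compound is tolerated:
compound 1 `COc1cccc(NC(=S)Nc2cccc(C(F)(F)F)c2)c1`: 26000 nM
compound 2 `FC(F)(F)c1cccc(NC(=S)Nc2cccc(Br)c2)c1`: 9200 nM
compound 3 `Fc1ccccc1NC(=S)Nc1cccc(C(F)(F)F)c1`: 47000 nM

Compound 3 stands within the scatter of compound 1 and well clear of compound 2. Compound 4 `Fc1cccc(NC(=S)Nc2cccc(C(F)(F)F)c2)c1` differs from compound 3 by 3-fluorophenyl in place of 2-fluorophenyl on an amide-type nitrogen. Two measured steps alter this same group, both modest: a 2.8-fold lower number from compound 1 to compound 2 (0.45 log units; beyond the scatter) and a 5.1-fold higher number from compound 2 to compound 3 (0.71 log units; beyond the scatter). Neither exchanges one fluorophenyl for another, so they only bound the expectation. Compound 4 shares fluoro with compound 3 and the 3-substituted phenyl name with compound 2, so a small move towards a lower number is expected. The expected step is a 1.8-fold lower number from compound 3 to compound 4 (0.26 log units; within the scatter). For compound 4 the estimate is 26000 nM, with an expected range of 11000 nM to 55000 nM.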

Compound 4, half-maximal cytotoxic concentration: 20000 nM
The estimate for compound 4 lay 1.3-fold (0.11 log units) above the measured number; low and high end bracket the measured number.
By their numbers in this assay, from the lowest: compound 2; then compounds 4, 1 and 3 (each within the scatter of the next, the first and the last beyond it).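

In this assay, 3-fluorophenyl in place of 2-fluorophenyl on the amide-type nitrogen, with the atoms unchanged, is a step in its own right (a 2.4-fold lower number from compound 3 to compound 4 (0.37 log units; beyond the scatter)). On the aromatic carbon, fluoro in place of bromo also gives a step beyond the scatter (a 2.2-fold higher number from compound 2 to compound 4 (0.34 log units; beyond the scatter)), whereas fluoro in place of methoxy stays within it (a 1.3-fold lower number from compound 1 to compound 4 (0.11 log units; within the scatter)). Nothing available bears on the cause of these steps. Still open, as far as these compounds go, is how an amine or a carboxylic acid on that aromatic carbon would compare with fluoro, bromo and methoxy.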